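A few compounds are considered here, and "the series" means these few. Any claim that something is new, unique, unknown or untested is made for them only; others in the source may bear on it.

Compound 1 `O=C(Nc1cccc(-n2cc(-c3ccncc3)c(-c3ccc(Cl)c(O)c3)n2)c1)Nc1cccc(C(F)(F)F)c1` is measured in a functional assay on SN12C cells (Homo sapiens) for inhibition, read by sulforhodamine B assay, with a stated time of 48 h (a higher number here means a weaker inhibitor of growth, a lower number a stronger inhibitor of growth), at 2010 nM. On the numbers shown it stands highest of the two; its nearest neighbour, compound 2 `COc1cc(-c2nn(-c3cccc(NC(=O)Nc4cccc(C(F)(F)F)c4)c3)cc2-c2ccncc2)ccc1Cl`, gives 1400 nM in this assay. Within the data shown here, the one step between them, a 1.4-fold lower number from compound 1 to compound 2 (0.16 log units; within the scatter), is a methyl in place of hydrogen on an oxygen on an aromatic ring, a change on a different part of the shared core from the one now considered. Compound 3 `O=C(Nc1cccc(-n2cc(-c3ccncc3)c(-c3ccc(Cl)c(O)c3)n2)c1)Nc1ccc(Cl)c(C(F)(F)F)c1` differs from compound 1 by chloro in place of hydrogen on an aromatic carbon. Among the measured compounds shown here, no measured step touches this end of the shared core, so the only guide is that the single change seen so far moved the number little. Compound 3 is therefore expected to show a step of a 1.7-fold lower number from compound 1 to compound 3 (0.22 log units; within the scatter), a modest lowering that may well sit within the scatter. The estimate for compound 3 in this assay is 1200 nM, with a range expected to run from 400 nM to 3500 nM.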

Compound 3, concentration for 50% growth inhibition: 1120 nM
Compound 3: the middle estimate sits 1.1-fold (0.03 log units) above what was measured; the measured number falls inside the stated range.
By their numbers in this assay, from the lowest: compounds 3, 2 and 1 (each within the scatter of the next).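

Chloro in place of hydrogen on an aromatic carbon, ortho to a trifluoromethyl group and para to a large group, gives a 1.8-fold lower number from compound 1 to compound 3 (0.25 log units; within the scatter) in this assay and so provides the first reading at this end of the shared core, which the earlier step did not touch. Since this step lies within the scatter, taking 3-(trifluoromethyl)phenyl to 4-chloro-3-(trifluoromethyl)phenyl leaves compound 1 and compound 3 not distinguishable in this read-out, so the added chloro is accommodated at this position without a measurable difference. No measured evidence bears on this result, and the numbers alone offer no explanation for it.

The compounds shown leave open whether any other group at this position, such as an amine, a carboxylic acid or a longer chain, would give a step beyond the scatter. They also leave open whether chloro at this position and the methyl on the oxygen, which are seen here only apart, would give a different number if carried together on the shared core.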